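The source may report more compounds than this note shows. Statements on the series, on what has been measured and on what is new or still open speak of the compounds shown alone.

Working notes. Going by the values given here, in a functional assay on MGC-803 cells (Homo sapiens) for inhibition, read by MTT assay, with a stated time of 48 h (on this read-out lower numbers stand for stronger inhibition and higher numbers for weaker inhibition), compound 2 `Cc1ccc(COc2ccc(C(=O)NC(=S)Nc3ccc(C)c(-c4nc5ccccc5[nH]4)c3)cc2)cc1` gives 4980 nM, the lowest of the two numbers so far; compound 1 `Cc1ccc(NC(=S)NC(=O)c2ccc(OCc3cccc(Cl)c3)cc2)cc1-c1nc2ccccc2[nH]1` gives 51300 nM. Among the compounds with values here, the single measured step, a 10-fold lower number from compound 1 to compound 2 (1.01 log units; beyond the scatter), shows that the aryl ring of the benzyl ether carries the whole spread seen to date. Compound 3 `Cc1ccc(NC(=S)NC(=O)c2ccc(OCc3ccc(F)cc3)cc2)cc1-c1nc2ccccc2[nH]1` differs from compound 2 by fluoro in place of methyl on an aromatic carbon. Within the data shown here, no measured step isolates this change; the only pointer is that compound 1, carrying a halogen on that ring, gave 51300 nM, so a moderate weakening is expected rather than none. For compound 3 in this assay the expected value is 12000 nM, range 3500 nM to 40000 nM. The expected step is a 2.4-fold higher number from compound 2 to compound 3 (0.38 log units; beyond the scatter).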

Compound 3, half-maximal inhibitory concentration: 2810 nM
Beside the measured number, compound 3's estimate is 4.3-fold (0.63 log units) above it; measured number outside the range, below it.
By their numbers in this assay, from the lowest: compounds 3 and 2 (each within the scatter of the next); then compound 1.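

In this assay, fluoro and methyl on an aromatic carbon para to a large group cannot be told apart, with a 1.8-fold lower number from compound 2 to compound 3 (0.25 log units; within the scatter). A halogen on this ring therefore does not by itself go with a high number, as shown by an 18-fold lower number from compound 1 to compound 3 (1.26 log units; beyond the scatter). No evidence on hand gives a reason for either step.

That second step changes both the halogen and its place on the ring, and the two effects remain unseparated. On these data alone, how a 4-chlorophenyl group, or a ring bearing a methoxy group, would read remains open.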